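Adding a Second Chloro Group and Growth Inhibition

This account rests on a few compounds, and the source may have more. Where it says the series, first, only, none or still open, it means among the compounds named here.

Of the compounds shown here, three have been tested in a functional assay on BT-549 cells (Homo sapiens) for cytotoxicity, read by sulforhodamine B assay, with a stated time of 48 h; on this read-out lower numbers stand for stronger inhibition of growth and higher numbers for weaker inhibition of growth. Compound 1 `ClCc1ccccc1Cn1cnc2c(Cl)nc(Cl)nc21` gives 1470 nM. Compound 2 `ClCc1ccccc1Cn1cnc2c(Cl)ncnc21` gives 5490 nM in this assay. Compound 3 `ClCc1cccc(Cn2cnc3ncnc(Cl)c32)c1` gives 28800 nM in this assay, the highest of the three numbers. Compounds 2 and 3 are built from the same atoms joined differently; the difference between their two cores is not broken down here.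

For the measured compounds named here, only one single-point change has been measured so far: chloro in place of hydrogen on an aromatic carbon. It gave a 3.7-fold lower number from compound 2 to compound 1 (0.57 log units; beyond the scatter).

Compound 4 `ClCc1cccc(Cn2cnc3nc(Cl)nc(Cl)c32)c1` has not yet been measured. It is made from compound 3 by chloro in place of hydrogen on an aromatic carbon, the same change as before, at a place described in the same words. Going by the values given here, because the only measured example of this change is a 3.7-fold lower number from compound 2 to compound 1 (0.57 log units; beyond the scatter), the expectation for compound 4 rests on that step alone, taken as roughly repeatable. For compound 4 the expected step is a 3.6-fold lower number from compound 3 to compound 4 (0.56 log units; beyond the scatter), because the same change gave a 3.7-fold lower number from compound 2 to compound 1 (0.57 log units; beyond the scatter). The expected value for compound 4 in this assay is 8000 nM, with a likely range from 3500 nM to 18000 nM.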

Compound 4, concentration for total growth inhibition: 1730 nM
Beside the measured number, compound 4's estimate is 4.6-fold (0.67 log units) above it; the measured number lies below the stated range.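

In this assay, the change gave a 17-fold lower number from compound 3 to compound 4 (1.22 log units; beyond the scatter), so the direction seen on the first core carried over to the second, but the size did not: the same change on two cores in this assay, a 3.7-fold lower number (0.57 log units; beyond the scatter) from compound 2 to compound 1 and a 17-fold lower number (1.22 log units; beyond the scatter) from compound 3 to compound 4, 4.5-fold (0.65 log units) apart, beyond the scatter of two such steps

In both pairs, chloro in place of hydrogen on an aromatic carbon went with stronger inhibition of growth, yet the step measured on one core was a poor guide to the size of the step on the other. Two pairs make no general rule, and they do not show why the sizes differ, since the data do not separate which feature of the two cores matters.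

The compounds shown leave open how a different group, such as an amine or a methoxy group, would behave at this same place, on an aromatic carbon between two ring nitrogen atoms. They also leave open whether such a group would give steps that differ between the two cores, as chloro does.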